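Swapping the aryl group from compound 3 to compound 4

The source may report more compounds than this note shows. Statements on the series, on what has been measured and on what is new or still open speak of the compounds shown alone.

In a functional assay on MCF7 cells (Homo sapiens) for antiproliferative activity, read by MTT assay, with stated times of 24 h and 72 h (a higher number here means a weaker inhibitor, a lower number a stronger inhibitor), compound 1 `COc1cc([C@@H]2[C@H](Oc3ccccc3)C(=O)N2c2cc(OC)c(OC)c(OC)c2)cc(OC)c1OC` gives 29000 nM, compound 2 `COc1ccc([C@@H]2[C@H](Oc3ccccc3)C(=O)N2c2cc(OC)c(OC)c(OC)c2)cc1` gives 35000 nM and compound 3 `COc1ccc([C@@H]2[C@H](Oc3ccccc3)C(=O)N2c2cc(OC)c(OC)c(OC)c2)cc1OC` gives 26000 nM. Compound 3 therefore stands level with the other two, with both gaps inside the scatter. The next compound is compound 4 `COc1cc(N2C(=O)[C@@H](Oc3ccccc3)[C@H]2c2ccc(Br)cc2)cc(OC)c1OC`, and the change is 4-bromophenyl in place of 3,4-dimethoxyphenyl on a saturated ring carbon. Within the data shown here, three measured steps bear on this aryl group: a 1.2-fold higher number from compound 1 to compound 2 (0.08 log units; within the scatter), a 1.1-fold lower number from compound 1 to compound 3 (0.05 log units; within the scatter) and a 1.3-fold lower number from compound 2 to compound 3 (0.13 log units; within the scatter). All three stay within the scatter, so varying the methoxy groups on this ring has not moved the number in this assay. Among the measured compounds shown here, no measured compound carries bromine, so this group is untested here and the range is kept wide. No shift beyond the scatter is expected in either direction, and the expected step is a 1.1-fold higher number from compound 3 to compound 4 (0.03 log units; within the scatter). Compound 4 is estimated at 28000 nM, with an expected range of 11000 nM to 70000 nM.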

Compound 4, half-maximal inhibitory concentration: 48000 nM
Compound 4: middle estimate off by 1.7-fold (0.23 log units), on the low side; measured number inside the range.
By their numbers in this assay, from the lowest: compounds 3, 1, 2 and 4 (each within the scatter of the next).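

In this assay, the new group gives a 1.8-fold higher number from compound 3 to compound 4 (0.27 log units; within the scatter) and the two other comparisons give a 1.4-fold higher number from compound 2 to compound 4 (0.14 log units; within the scatter) and a 1.7-fold higher number from compound 1 to compound 4 (0.22 log units; within the scatter), all within the scatter. This saturated ring carbon therefore carries 4-bromophenyl, with bromine and no methoxy on the ring and 0 hydrogen-bond acceptors in the group, with no step beyond the scatter from any of the methoxy-bearing aryl groups, so no methoxy group on this ring is shown to be needed for the number to stay in this range. Nothing at hand offers an explanation for this flat picture. Every compound shown keeps an aryl ring at this carbon and the rest of the core unchanged. As far as these compounds go, whether an amine or carboxylic acid on this ring, or a hydroxyl in place of the phenoxy group, would produce a step beyond the scatter remains open.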